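Swapping an Anilide for a Benzylamide in a Weak Series

This account rests on a few compounds, and the source may have more. Where it says the series, first, only, none or still open, it means among the compounds named here.

Compound 1 `Cc1ccc(NC(=O)c2cccc(/C=C3\CC(=O)N(c4ccccc4)C3=O)c2)cc1`: > 100000 nM
Compound 2 `CCc1cccc(NC(=O)c2cccc(/C=C3\CC(=O)N(c4ccccc4)C3=O)c2)c1`: 88600 nM

For the measured compounds named here, in an ADME assay on SW480 cells (Homo sapiens) for cytotoxicity, read by MTT assay, with a stated time of 72 h (a lower number here means a stronger inhibitor, a higher number a weaker inhibitor), compound 2 stands as the only numeric value among the two measured compounds, and that value is weak. Compound 1 reports a limit rather than a number, namely (the limit of > 100000 nM in this assay, at which 1 of the 2 values shown sits). Going by the values given here, the one measured step, an at least 1.1-fold lower number from compound 1 to compound 2 (0.05 log units; that floor lies within the scatter), exchanges one aryl group for another on the amide-type nitrogen and lies within the scatter, so it gives no sign of a real shift in this assay.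

Compound 3 `O=C(NCc1ccccc1)c1cccc(/C=C2\CC(=O)N(c3ccccc3)C2=O)c1` has not yet been measured. It differs from compound 2 in one place: benzyl in place of 3-ethylphenyl on an amide-type nitrogen. Among the compounds with values here, no measured step covers a change from an aryl group to benzyl at this nitrogen, so the only guidance is that the one step seen, from an aryl to another aryl, was within the scatter, and that both measured compounds sit at the weak end of the range. Compound 3 is thus expected to show a 1.1-fold higher number from compound 2 to compound 3 (0.05 log units; within the scatter), a step not expected to exceed the scatter. Compound 3 is estimated at 100000 nM, with a range from 35000 nM to 300000 nM, and the measurement may well return only a limit.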

Compound 3, half-maximal inhibitory concentration: > 100000 nM
Compound 3: a limit, no number; the forecaster's own chance of this, stated with the estimate: 45%; the middle value sits exactly at the limit.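

For the compounds shown here, the change from an aryl group to benzyl on the amide-type nitrogen, which no earlier step covered, gives in this assay an at least 1.1-fold higher number from compound 2 to compound 3 (0.05 log units; that floor lies within the scatter). This floor shows no shift beyond the scatter, although it does not exclude a larger one. Compound 3 reports a limit rather than a number, and the step that joins it to compound 1 cannot be read. With 4-methylphenyl, 3-ethylphenyl and benzyl now seen on this nitrogen, only compound 2 gives a number, and the other two compounds stop at the same limit: the limit of > 100000 nM in this assay, at which 2 of the 3 values shown sit.

As far as these compounds go, how far compound 1 and compound 3 lie past that limit remains open, and so does whether any real difference separates the three groups. Also open, from the compounds shown here alone, is whether a group of another kind on this nitrogen, such as a chain ending in an amine or a benzyl group carrying a carboxylic acid, would bring the number into a range where steps can be read.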